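Ring Size on the Amide Nitrogen of Compound 1

The source may report more compounds than this note shows. Statements on the series, on what has been measured and on what is new or still open speak of the compounds shown alone.

Measured compounds:
Compound 1 `Cc1cccc(C#Cc2ccc3c(n2)CCN(C2CCCC2)C3=O)c1` gives 670 nM in an assay on HEK293 cells for displacement of a labelled ligand from metabotropic glutamate receptor 5 (Homo sapiens), with a stated time of 2 h; on this read-out lower numbers stand for stronger inhibition and higher numbers for weaker inhibition.
Compound 2 `O=C1c2ccc(C#Cc3ccc(Cl)cc3)nc2CCN1C1CCCC1` shows only a limit in this assay, > 32000 nM.
Compound 3 `O=C1c2ccc(C#Cc3cccs3)nc2CCN1C1CCCC1` gives 2840 nM in this assay.

Among the numbers shown, compound 1 has the lowest; its nearest neighbour is compound 3, with a 4.2-fold higher number from compound 1 to compound 3 (0.63 log units; beyond the scatter). For compound 2 the assay reports no number, only (the limit of > 32000 nM in this assay, at which 1 of the 3 values shown sits). The steps of an at least 47-fold higher number from compound 1 to compound 2 (1.67 log units; beyond the scatter) and an at least 11-fold lower number from compound 2 to compound 3 (1.05 log units; beyond the scatter) both change the group on the triple-bonded carbon, as does the step to compound 3, and none of them alters the amide-type nitrogen.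

Compound 4 `Cc1cccc(C#Cc2ccc3c(n2)CCN(C2CCCCC2)C3=O)c1` differs from compound 1 in one place: cyclohexyl in place of cyclopentyl on an amide-type nitrogen in a ring. Within the data shown here, no measured step bears on this change, so no step beyond the scatter is expected in this assay. Compound 4 is therefore estimated to give 670 nM, with a range from 250 nM to 1800 nM. This expected value would mean no change at the digits printed from compound 1 to compound 4 (within the scatter).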

Compound 4, inhibition constant: 3210 nM
Compound 4: the middle estimate sits 4.8-fold (0.68 log units) below what was measured; measured number outside the range, above it.
By their numbers in this assay, from the lowest: compound 1; then compounds 3 and 4 (each within the scatter of the next). At a limit, above all of these: compound 2.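

Until now only the group on the triple-bonded carbon had been seen to move the number. In this assay, cyclohexyl in place of cyclopentyl on the amide-type nitrogen in a ring gives a 4.8-fold higher number from compound 1 to compound 4 (0.68 log units; beyond the scatter), so this position also responds, even to a change from a five-membered to a six-membered carbon ring. Nothing in the data shown accounts for this step. Going by these compounds, how a cyclobutyl, an isopropyl or a tetrahydropyran-4-yl group would read at this nitrogen stays open. So does whether the cyclohexyl step holds with thiophen-2-yl on the triple-bonded carbon.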